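The source may hold more compounds than are shown below. What is called first, only, known or untested is meant among the compounds shown, and "the series" means these compounds.

Measured in a physicochemical assay for lipophilicity, read by HPLC, measured as octanol-water partition; on this read-out lower numbers stand for lower lipophilicity and higher numbers for higher lipophilicity:
- compound 1 `O=C(CSc1ncnc2c1cnn2-c1ccccc1Cl)Nc1ccccc1`: 4.3
- compound 2 `Cc1ccc(NC(=O)CSc2ncnc3c2cnn3-c2ccccc2Cl)nc1`: 4.2

Compound 2 stands level with compound 1, the step being a number 0.10 log units lower from compound 1 to compound 2 (within the scatter). Compound 3 `O=C(CSc1ncnc2c1cnn2-c1ccccc1Cl)Nc1ncccn1` differs from compound 2 by pyrimidin-2-yl in place of 5-methylpyridin-2-yl on an amide-type nitrogen, in words pyrimidin-2-yl in place of 5-methylpyridin-2-yl on an amide-type nitrogen. Among the measured compounds shown here, only one measured step bears on this place, a number 0.10 log units lower from compound 1 to compound 2 (within the scatter), and it did not involve pyrimidin-2-yl, so it is a weak guide. With carbon lost and a hetero atom gained, a fall beyond the scatter is nevertheless expected, estimated as a number 0.60 log units lower from compound 2 to compound 3 (beyond the scatter). For compound 3 the expected value is 3.6, with an estimated range of 3.1 to 4.1.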

Compound 3, distribution coefficient: 2.2
Beside the measured number, compound 3's estimate is 1.40 log units above it; the measured number lies below the stated range.
By their numbers in this assay, from the lowest: compound 3; then compounds 2 and 1 (each within the scatter of the next).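

At this place on the amide-type nitrogen, this assay proves highly sensitive to the ring: pyrimidin-2-yl in place of 5-methylpyridin-2-yl gives a number 2.00 log units lower from compound 2 to compound 3 (beyond the scatter) and pyrimidin-2-yl in place of phenyl gives a number 2.10 log units lower from compound 1 to compound 3 (beyond the scatter) on the same read-out. The earlier exchange of phenyl for 5-methylpyridin-2-yl had shown no such sensitivity, its step staying within the scatter. Nothing available explains the size of this fall.

The compounds shown leave open where an unsubstituted pyridin-2-yl would fall. They also leave open whether a pyrimidin-2-yl ring bearing a methyl group or an amine would keep the low number.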